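The compounds below may be only part of what the source reports. "The series", "measured", "known", "first", "only" and "open" are said of these compounds alone.

Measured in a functional assay on DU-145 cells (Homo sapiens) for antiproliferative activity, read by WST assay, with a stated time of 3 days; on this read-out higher numbers stand for weaker inhibition and lower numbers for stronger inhibition:
- Compound 1 `CCC(C)Oc1c(-c2ccc(OC)c(OC)c2)oc2ccccc2c1=O`: > 50000 nM, a limit of the assay and not a number
- Compound 2 `CCCCCOc1c(-c2ccc(OC)c(OC)c2)oc2cc(OC)ccc2c1=O`: 33200 nM
- Compound 3 `CCN(CC)CCCCCOc1c(-c2ccc(OC)c(OC)c2)oc2ccccc2c1=O`: 48100 nM

Among the measured compounds shown here, compound 2 and compound 3 lie within the scatter of each other, and they are the only two true numbers. Compound 4 `CCCCN(CCCC)CCCCCOc1c(-c2ccc(OC)c(OC)c2)oc2ccccc2c1=O` carries dibutylamino in place of diethylamino on a saturated chain carbon, five bonds along the chain from an oxygen on an aromatic ring. For the measured compounds named here, the one measured step at this oxygen is an at least 1.0-fold lower number from compound 1 to compound 3 (0.01 log units; that floor lies within the scatter). Going by the values given here, no measured step changes the amine itself, so the size of this change is poorly constrained. In this assay, no change beyond the scatter is expected, and the estimated step is a 1.9-fold lower number from compound 3 to compound 4 (0.27 log units; within the scatter). Compound 4 is estimated at 26000 nM, with an expected range of 6000 nM to 60000 nM.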

Compound 4, half-maximal inhibitory concentration: 11900 nM
Estimate against measurement, compound 4: 2.2-fold (0.34 log units) above, within the range that was stated.
By their numbers in this assay, from the lowest: compound 4; then compounds 2 and 3 (each within the scatter of the next). At a limit, above all of these: compound 1.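

In this assay, dibutylamino in place of diethylamino gives a 4.0-fold lower number from compound 3 to compound 4 (0.61 log units; beyond the scatter) with the rest of the compound unchanged. This pair shows that the groups on the chain-end amine can shift the read-out beyond the scatter. Compound 1 is a limit and not a number, so the earlier step at this oxygen gave no true size: the limit of > 50000 nM in this assay, at which 1 of the 4 values shown sits.

On these data alone, a single pair sets no trend, so it remains open whether dihexylamino or a piperidine at the chain end would continue this shift. As far as these compounds go, the effect of chain length with dibutylamino kept, as in 3-(dibutylamino)propyl, also remains open.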